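Chlorine Placement on the Benzylsulfanyl Arm

The source may report more compounds than this note shows. Statements on the series, on what has been measured and on what is new or still open speak of the compounds shown alone.

Of the compounds shown here, three share one core and have been tested in a functional assay on the whole organism (artery, strain albino) with Rattus norvegicus as the target, with a stated time of 15 min, at a dose of 10 mg/kg by the oral route; on this read-out lower numbers stand for less inhibition and higher numbers for more inhibition at the one dose given (going by the name of the read-out). Compound 1 `CC1=C(C(=O)Nc2ccc(Br)cc2)C(c2ccc(Cl)cc2Cl)N=C(SCc2ccc(Cl)cc2)N1` gives 4.1%. Compound 2 `COc1ccc(C2N=C(SCc3ccccc3Cl)NC(C)=C2C(=O)Nc2ccc(Br)cc2)cc1` gives 3.1%, and compound 3 `COc1ccc(C2N=C(SCc3cccc(Cl)c3)NC(C)=C2C(=O)Nc2ccc(Br)cc2)cc1` gives 3.1%. On these numbers compound 3 stands level with compound 2, the two together forming the lowest pair of the three, and compound 1 sits only a shade higher, within the scatter of the method. None of the three shows inhibition of note at this dose.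

Compound 4 `COc1ccc(C2N=C(SCc3ccc(Cl)cc3)NC(C)=C2C(=O)Nc2ccc(Br)cc2)cc1` has the same atoms as compound 3, joined differently: 4-chlorophenyl in place of 3-chlorophenyl on a saturated chain carbon bound to a sulfur. Within the data shown here, the one measured step that bears on this kind of swap, no change at the digits printed from compound 2 to compound 3 (within the scatter), was of the same sort and produced no change. Compound 1, which also carries a 4-chlorophenyl on the saturated chain carbon bound to a sulfur, though it differs elsewhere too, likewise shows a low value. For compound 4 the expected step is a number 0.4 percentage points higher from compound 3 to compound 4 (within the scatter), nothing beyond the scatter. Compound 4 is therefore estimated at 3.5%, between -5% and 12%.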

Compound 4, a percentage reported as inhibition, in the whole organism at one dose (the size of the read-out at that dose, not a potency): 3.1%
The estimate for compound 4 lay 0.4 percentage points above the measured number; low and high end bracket the measured number.
By their numbers in this assay, from the lowest: compounds 2, 3, 4 and 1 (each within the scatter of the next).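

In this assay, the chlorine's third placement gives no change at the digits printed from compound 3 to compound 4 (within the scatter) and no change at the digits printed from compound 2 to compound 4 (within the scatter), so the 2-chlorophenyl, 3-chlorophenyl and 4-chlorophenyl groups on a saturated chain carbon bound to a sulfur now all read alike, where before only two of them could be compared. A second place in the molecule also gets a single-change comparison, with 4-methoxyphenyl in place of 2,4-dichlorophenyl on a saturated ring carbon giving a number 1 percentage points lower from compound 1 to compound 4 (within the scatter), so this swap does not stand out from the scatter either. No accompanying measurement offers an explanation for these results.

All four values are low, so the compounds shown do not reveal whether any change at either place can raise inhibition at this dose. As far as these compounds go, whether an amine or a carboxylic acid in place of the chlorine, or a longer chain on the sulfur, would read differently stays open.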